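A few compounds are considered here, and "the series" means these few. Any claim that something is new, unique, unknown or untested is made for them only; others in the source may bear on it.

Notes on the series. In a functional assay on HeLa cells (Homo sapiens) for antiproliferative activity, read by MTT assay, with a stated time of 48 h (on this read-out higher numbers stand for weaker inhibition and lower numbers for stronger inhibition), compound 1 (`CN(C)CCn1c(N)c(-c2nc3ccccc3[nH]2)c2nc(C#N)c(C#N)nc21`) gives 8880 nM. Compound 2 (`CN(C)CCn1c(N)c(-c2nc3ccccc3n2C)c2nc(C#N)c(C#N)nc21`) reads > 50000 nM, which is a limit of the assay and not a number.

Compound 3 (`CCN(CC)CCCCn1c(N)c(-c2nc3ccccc3n2C)c2nc(C#N)c(C#N)nc21`) keeps everything in compound 2 except the chain: 2-(diethylamino)ethyl in place of dimethylamino on a saturated chain carbon, two bonds along the chain from an aromatic nitrogen. Cut one bond further out, this reads 2-(dimethylamino)ethyl to 4-(diethylamino)butyl.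

Among the measured compounds shown here, the only measured step is an at least 5.6-fold higher number from compound 1 to compound 2 (0.75 log units; beyond the scatter). For the measured compounds named here, it lies at another place in the structure, so no measured step speaks directly to this chain change. It does show that compound 1, at 8880 nM, reaches a measurable range on the shared core. A modest move towards lower numbers in this assay is therefore expected, and compound 3 may well stay at the limit. The expected step is an at least 2.0-fold lower number from compound 2 to compound 3 (0.30 log units; that floor lies within the scatter). For compound 3 the estimated value is 25000 nM, with an expected range of 8000 nM to 60000 nM.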

Compound 3, half-maximal inhibitory concentration: 1610 nM
Beside the measured number, compound 3's estimate is 16-fold (1.19 log units) above it; the measured number lies below the stated range.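

In this assay, the change of chain gives an at least 31-fold lower number from compound 2 to compound 3 (1.49 log units; beyond the scatter), the first sign that this position has a large bearing on the read-out. The methyl on the aromatic nitrogen, which came with an at least 5.6-fold higher number from compound 1 to compound 2 (0.75 log units; beyond the scatter), therefore does not by itself rule out a measured number, since compound 3 carries that methyl and gives 1610 nM. The step is a floor and not a full size, because the value of compound 2 is a limit of the assay and not a number: the limit of > 50000 nM in this assay, at which 1 of the 3 values shown sits.

The change from 2-(dimethylamino)ethyl to 4-(diethylamino)butyl alters chain length and the groups on the amine together, and the compounds shown do not separate the two; a 4-(dimethylamino)butyl chain would. Also open, as far as these compounds go, are a longer chain, a piperidine at the chain end, and the 4-(diethylamino)butyl chain paired with the hydrogen on the aromatic nitrogen in place of methyl.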